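The source may report more compounds than this note shows. Statements on the series, on what has been measured and on what is new or still open speak of the compounds shown alone.

Compound 1 `O=C(CCCc1ccccc1)CC(=O)N[C@H]1CCOC1=O`: > 100000 nM
Compound 2 `O=C(CCCCCCCCCCc1ccccc1)N[C@H]1CCOC1=O`: 66000 nM

Both measured compounds share the same core and were tested in a functional assay on PC-3 cells (Homo sapiens) for cytotoxicity, read by sulforhodamine B assay, with a stated time of 5 days; a lower number here means a stronger inhibitor, a higher number a weaker inhibitor. For compound 1 the figure is a limit of the assay and not a number: the limit of > 100000 nM in this assay, at which 1 of the 2 values shown sits. In this assay compound 2 gives 66000 nM, so both readings sit at the weak end of the range. Within the data shown here, no two measured compounds differ in only one place, so no measured step is available to lean on.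

Compound 3 `O=C(CCc1ccccc1)CC(=O)N[C@H]1CCOC1=O` has not yet been tested. It differs from compound 1 by phenyl in place of benzyl on a saturated chain carbon, two bonds along the chain from a carbonyl carbon. With compound 1 already at the limit, the change has little room to show as a weakening, and the measured compounds give no ground to expect a strengthening beyond the usual scatter. The step expected in this assay is a step that the limit leaves unreadable from compound 1 to compound 3, none beyond the scatter. Compound 3 is therefore expected to give 150000 nM, within a range from 50000 nM to 500000 nM, with a fair chance that the assay again reports only a limit.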

Compound 3, half-maximal inhibitory concentration: > 100000 nM
Compound 3 was reported as a limit (the forecaster's own chance of this, stated with the estimate: 70%); the middle value is on the limit's open side.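

Compound 1 and compound 3 are each reported in this assay only as a limit and not as a number, and no step can be read between them. The compounds shown leave open how strong either one is in this assay, and whether phenyl in place of benzyl on a saturated chain carbon makes any difference there.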